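This account rests on a few compounds, and the source may have more. Where it says the series, first, only, none or still open, it means among the compounds named here.

The measured compounds in brief:
Compound 1, `C=C(Br)C(=O)Nc1ccc(/C=C2\SC(=O)N(Cc3ccc(Cl)cc3)C2=O)cc1`, gives 5100 nM in a functional assay on FM3A cells (Mus musculus) for cytotoxicity, read by cell counting, with a stated time of 2 days; a lower number here means a stronger inhibitor, a higher number a weaker inhibitor.
Compound 2, `C=C(Br)C(=O)Nc1ccc(/C=C2\SC(=O)N(Cc3ccc(C(F)(F)F)cc3)C2=O)cc1`, gives 23000 nM in this assay.
Compound 3, `C=C(Br)C(=O)Nc1cccc(/C=C2\SC(=O)N(Cc3ccc(C(F)(F)F)cc3)C2=O)c1`, gives 870 nM in this assay.

Compounds 1 and 2 share one core and differ in a single place, namely (chloro in place of trifluoromethyl on an aromatic carbon). In this assay that change made a step of a 4.5-fold lower number from compound 2 to compound 1 (0.65 log units; beyond the scatter). Compound 3 is built from the same atoms as compound 2 but joined differently; the difference between the two cores is not broken down here. In this assay compound 3 gives the lowest of the three numbers, and its gaps to compound 1 and to compound 2 both lie beyond the scatter.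

Compound 4, `C=C(Br)C(=O)Nc1cccc(/C=C2\SC(=O)N(Cc3ccc(Cl)cc3)C2=O)c1`, has not yet been measured in this assay. It differs from compound 3 by chloro in place of trifluoromethyl on an aromatic carbon, the same change that separates compound 2 from compound 1, at the same place on the same kind of ring. The expectation for compound 4 rests on the step of a 4.5-fold lower number from compound 2 to compound 1 (0.65 log units; beyond the scatter) that this change produced on the other core, with the caution that the change has been seen only once and need not carry over unchanged. In this assay compound 4 is therefore expected to give about 250 nM, most likely between 80 nM and 900 nM. For compound 4 this means an expected step of a 3.5-fold lower number from compound 3 to compound 4 (0.54 log units; beyond the scatter).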

Compound 4, half-maximal inhibitory concentration: 1600 nM
Beside the measured number, compound 4's estimate is 6.4-fold (0.81 log units) below it, and the stated range ends below it.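

In this assay, putting chloro in place of trifluoromethyl on the core of compound 3 gave a 1.8-fold higher number from compound 3 to compound 4 (0.26 log units; within the scatter), so on this core the change cannot be distinguished from the scatter, whereas on the core of compound 1 it was a step beyond the scatter. Set side by side, the two results do not agree, and the step seen on one core did not carry over to the other: the same change on two cores in this assay, a 4.5-fold lower number (0.65 log units; beyond the scatter) from compound 2 to compound 1 and a 1.8-fold higher number (0.26 log units; within the scatter) from compound 3 to compound 4, 8.3-fold (0.92 log units) apart, beyond the scatter of two such steps. Within these four compounds, the outcome of this change therefore depends on the core, but two cores cannot show why it does so or predict what the change would do on a further core.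

The compounds shown leave open how groups other than chloro and trifluoromethyl, such as a methoxy group, a nitrile or an amine, would behave at this place on the ring, and whether those groups would also differ between the two cores. They also leave open what would happen on either core if the bromine of the amide side chain gave way to hydrogen or to chlorine, since all four compounds carry that same bromine.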